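Adding a chain to the amide of compound 1

A few compounds are considered here, and "the series" means these few. Any claim that something is new, unique, unknown or untested is made for them only; others in the source may bear on it.

- compound 1 `Cc1cc2c(C(N)=O)cccc2n1-c1nc2c(c(NCc3ccccc3)n1)COCC2` gives 146 nM
- compound 2 `C#CCNC(=O)c1cccc2c1cc(C)n2-c1nc2c(c(NCc3ccccc3)n1)CCCC2` gives 470 nM
- compound 3 `CCCNC(=O)c1cccc2c1cc(C)n2-c1nc2c(c(NCc3ccccc3)n1)CCCC2` gives 608 nM

These values come from a functional assay on MIA PaCa-2 cells (Homo sapiens) for antiproliferative activity (a lower number here means that less compound is needed, a higher number that more compound is needed for the effect), and compound 1 has the lowest number of the three, with compound 2 and compound 3 both higher by more than the scatter. Compound 4 `CC#CCNC(=O)c1cccc2c1cc(C)n2-c1nc2c(c(NCc3ccccc3)n1)COCC2` has not yet been measured. It differs from compound 1 by but-2-yn-1-yl in place of hydrogen on an amide-type nitrogen in short, but-2-yn-1-yl in place of hydrogen on an amide-type nitrogen.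

Among the compounds with values here, no measured step covers this change directly. Within the data shown here, the one step available is a 1.3-fold higher number from compound 2 to compound 3 (0.11 log units; within the scatter) and it shows only that swapping one chain for another left the number within the scatter. It says nothing about adding a chain where there was none. The closer hint is indirect: compound 2 at 470 nM and compound 3 at 608 nM both carry a chain on that nitrogen, and both sit above compound 1. A moderate move to a higher number is therefore expected, with wide uncertainty. The expected change is a 2.4-fold higher number from compound 1 to compound 4 (0.38 log units; beyond the scatter) in this assay as an estimate. For compound 4 the estimated value is 350 nM with an expected range from 130 nM to 900 nM as its limits.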

Compound 4, half-maximal effective concentration: 524 nM
Beside the measured number, compound 4's estimate is 1.5-fold (0.18 log units) below it; low and high end bracket the measured number.
By their numbers in this assay, from the lowest: compound 1; then compounds 2, 4 and 3 (each within the scatter of the next).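

Each earlier compound with a chain on this nitrogen also differed from compound 1 in the core, so those compounds could only hint at what the chain itself does. With the core held constant, placing but-2-yn-1-yl on the amide-type nitrogen in this assay gives a 3.6-fold higher number from compound 1 to compound 4 (0.55 log units; beyond the scatter), showing that adding this chain in place of the amide hydrogen moves the number beyond the scatter. The step is modest, however, and compound 4 still gives a measurable value of 524 nM, so this chain raises the amount of compound needed without abolishing the effect. Nothing available explains why the number moves.

From the compounds shown here alone, whether any chain on this nitrogen would produce a similar step, or whether the result is specific to but-2-yn-1-yl with its triple bond, remains open. A methyl group, a saturated butyl chain, or a chain ending in an amine or a carboxylic acid, each on the same nitrogen of the core of compound 1, would help separate these possibilities.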